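The compounds below may be only part of what the source reports. "The series", "measured", "known", "first", "only" and "open" are said of these compounds alone.

Measured so far:
compound 1: `COc1cc(NC(=O)Nc2cc(Nc3ccc(F)c(Cl)c3)ncn2)cc(OC)c1`, 53%
compound 2: `CCc1cccc(Nc2cc(NC(=O)Nc3cc(OC)cc(OC)c3)ncn2)c1`, 27.7%

Both were tested in a functional assay on NCI-H1581 cells (Homo sapiens) for inhibition, read by MTT assay, with a stated time of 48 h, tested at 10 uM; on this read-out higher numbers stand for more inhibition at the one concentration tested (going by the name of the read-out) and lower numbers for less inhibition. Compound 2 stands lowest of the two numbers; its nearest neighbour is compound 1, and the step of a number 25.3 percentage points lower from compound 1 to compound 2 (beyond the scatter) shows that exchanging the group on this nitrogen moved the read-out beyond the scatter. Compound 3, `COc1cc(NC(=O)Nc2cc(Nc3ccc(Br)cc3OC)ncn2)cc(OC)c1`, is not yet measured. It differs from compound 2 in one place: 4-bromo-2-methoxyphenyl in place of 3-ethylphenyl on a nitrogen on an aromatic ring. Among the compounds with values here, only that one measured step bears on this change, since it too exchanged the whole group on that nitrogen, and it was modest in size. Compound 3 carries a bromine on its ring, as compound 1 carries a chlorine and a fluorine, rather than the ethyl of compound 2, so a rise of broadly similar size is expected, though the new group matches neither measured one. For compound 3 the expected step in this assay is a number 17.3 percentage points higher from compound 2 to compound 3 (beyond the scatter), giving an estimate of 45% with a range from 20% to 70%.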

Compound 3, a percentage reported as inhibition, at one concentration (the size of the read-out at that concentration, not a potency): 20.1%
Compound 3: the middle estimate sits 24.9 percentage points above what was measured; measured number inside the range.
By their numbers in this assay, from the lowest: compounds 3 and 2 (each within the scatter of the next); then compound 1.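

In this assay, exchanging 3-ethylphenyl for 4-bromo-2-methoxyphenyl on this nitrogen gives a number 7.6 percentage points lower from compound 2 to compound 3 (within the scatter), so these two groups cannot be told apart here. The comparison with the group of compound 1 gives a number 32.9 percentage points lower from compound 1 to compound 3 (beyond the scatter), which makes 3-chloro-4-fluorophenyl the only group shown that stands apart from both others, and compound 3 shows that a halogen on this ring does not by itself go with the higher number. Nothing available explains why these groups differ.

Compound 3 brings the bromine and the methoxy in together, so the compounds shown leave open what each contributes alone. Also open, as far as these compounds go, is how the read-out would respond to a phenyl ring on this nitrogen carrying a dimethylamino group or a carboxylic acid.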